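The source may report more compounds than this note shows. Statements on the series, on what has been measured and on what is new or still open speak of the compounds shown alone.

Measured compounds: compound 1 `O=C(O)CC1CC(CNC(=O)CCCNc2nccs2)=CCc2ccccc21` gives 40 nM in a functional assay on IGROV-1 cells (Homo sapiens) for inhibition; on this read-out higher numbers stand for weaker inhibition and lower numbers for stronger inhibition; compound 2 `O=C(O)CC1CC(CNC(=O)CCCNc2nc3ccccc3[nH]2)=CCc2ccccc21` gives 1.8 nM in this assay.

Compound 2 stands lowest of the two numbers, with compound 1 the nearest. For the measured compounds named here, the one measured step, a 22-fold lower number from compound 1 to compound 2 (1.35 log units; beyond the scatter), shows that the group on the amine nitrogen matters greatly. Compound 3 `O=C(O)CC1CC(CNC(=O)CCCNC2=NCCCN2)=CCc2ccccc21` differs from compound 2 by a group of 6 heavy atoms (4 carbon, 2 nitrogen; one six-membered non-aromatic ring with 2 hetero atoms) in place of a group of 9 heavy atoms (7 carbon, 2 nitrogen; one five-membered aromatic ring with 2 hetero atoms, one six-membered aromatic ring of carbon only), on an amine nitrogen. Going by the values given here, no measured step covers this exact exchange, so the direction is uncertain; a modest weakening is expected, a 2.8-fold higher number from compound 2 to compound 3 (0.44 log units; beyond the scatter). Compound 3 is estimated at 5 nM, ranging from 1 nM to 40 nM.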

Compound 3, half-maximal inhibitory concentration: 2.7 nM
For compound 3 the middle estimate is 1.9-fold (0.27 log units) above the measured one, and the stated range covers the measured number.
By their numbers in this assay, from the lowest: compounds 2 and 3 (each within the scatter of the next); then compound 1.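

A fused aromatic ring system is not required on this amine nitrogen: the non-aromatic six-membered ring with 2 hetero atoms does as well as 1H-benzimidazol-2-yl (a 1.5-fold higher number from compound 2 to compound 3 (0.18 log units; within the scatter)). The large gain over 1,3-thiazol-2-yl is therefore shared by two quite different groups (a 15-fold lower number from compound 1 to compound 3 (1.17 log units; beyond the scatter)). Nothing available explains this result.

Still open, on these data alone, is how a plain phenyl group or an open-chain guanidine would behave on this nitrogen. Also open, as far as these compounds go, is whether a longer chain leading to the amine would keep these low numbers.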